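The source may hold more compounds than are shown below. What is called first, only, known or untested is meant among the compounds shown, and "the series" means these compounds.

Working notes on the series. Compound 1 `CCCCNc1nc(N)nc2c1CNCC2` is the parent with a free ring amine; in an assay on HEK293 cells for agonist activity at Toll-like receptor 8 (Homo sapiens), read by a luciferase reporter, with a stated time of 6 h (on this read-out higher numbers stand for an effect only at larger amounts of compound and lower numbers for an effect already at smaller amounts), compound 1 gives 7.2 uM. Compound 2 `CCCCNc1nc(N)nc2c1CN(Cc1cccnc1)CC2` carries (pyridin-3-yl)methyl on that nitrogen, and in this assay compound 2 gives 0.13 uM. Compound 3 `CCCCNc1nc(N)nc2c1CN(C(=O)CC)CC2` carries propanoyl there, and in this assay compound 3 gives 0.4 uM. Compound 3 thus stands second highest of the three numbers: an 18-fold lower number from compound 1 to compound 3 (1.26 log units; beyond the scatter), while a 3.1-fold higher number from compound 2 to compound 3 (0.49 log units; beyond the scatter).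

The next step keeps the amide and changes its acyl part. Compound 4 `CCCCNc1nc(N)nc2c1CN(C(=O)c1cnc(C)cn1)CC2` differs from compound 3 by 5-methylpyrazin-2-yl in place of ethyl on a carbonyl carbon.

For the measured compounds named here, two measured steps bear on this. Substitution of the ring amine nitrogen was large in both cases, a 55-fold lower number from compound 1 to compound 2 (1.74 log units; beyond the scatter) and an 18-fold lower number from compound 1 to compound 3 (1.26 log units; beyond the scatter), and the step of a 3.1-fold higher number from compound 2 to compound 3 (0.49 log units; beyond the scatter) shows that (pyridin-3-yl)methyl gave the lower number of the two substituents. Compound 4 brings a six-membered aromatic ring with two hetero atoms into the acyl part, on the carbonyl carbon. Going by the values given here, no measured step tests a change within the acyl group itself, so the expectation rests on the comparison of compound 2 with compound 3 and is held to a modest size. The expected step is toward a lower number: a 2.7-fold lower number from compound 3 to compound 4 (0.43 log units; beyond the scatter). Compound 4 is estimated in this assay at 0.15 uM, with a range from 0.05 uM to 0.5 uM.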

Compound 4, minimum effective concentration: 6.8 uM
Compound 4: middle estimate off by 45-fold (1.66 log units), on the low side; the measured number lies above the stated range.
By their numbers in this assay, from the lowest: compound 2; then compound 3; then compounds 4 and 1 (each within the scatter of the next).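

In this assay, for the compounds shown here, the step of a 17-fold higher number from compound 3 to compound 4 (1.23 log units; beyond the scatter) is the first measured change within the acyl part, and it shows that the group on the carbonyl carbon strongly moves the number, with 5-methylpyrazin-2-yl entering in place of ethyl. An amide on the ring nitrogen therefore does not by itself carry the drop seen in an 18-fold lower number from compound 1 to compound 3 (1.26 log units; beyond the scatter): compound 4 at 6.8 uM lies within the scatter of the parent, compound 1 at 7.2 uM. An aromatic ring in the substituent also does not by itself go with a low number, since compound 2, with (pyridin-3-yl)methyl, gives 0.13 uM, and no measurement given here accounts for the step.

Open, from the compounds shown here alone, is whether the higher number follows the aromatic ring as such, its hetero atoms or its methyl, a question that benzoyl, unsubstituted pyrazin-2-yl or a longer acyl chain such as butanoyl on the same carbonyl carbon would help to separate. Also open, going by these compounds, is how pyridine-3-carbonyl would read, as it would place the ring of compound 2 directly on a carbonyl carbon.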